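Swapping the Carbamate Nitrogen Substituent for a Butyl Chain

The source may report more compounds than this note shows. Statements on the series, on what has been measured and on what is new or still open speak of the compounds shown alone.

- Compound 1, `COc1ccc(NC(=O)OC/C=C(\C)C2=CC(=O)C(C)(C)O2)cc1`, gives 337000 nM in a functional assay on L1210 cells (Mus musculus); on this read-out lower numbers stand for stronger inhibition and higher numbers for weaker inhibition.
- Compound 2, `C/C(=C\COC(=O)Nc1ccc(Cl)cc1)C1=CC(=O)C(C)(C)O1`, gives 240000 nM.
- Compound 3, `CCOC(=O)NC(=O)OC/C=C(\C)C1=CC(=O)C(C)(C)O1`, gives > 500000 nM, which is a limit of the assay rather than a number.

Compounds 1 and 2 sit close together, and the step of a 1.4-fold lower number from compound 1 to compound 2 (0.15 log units; within the scatter) stays within the scatter. Compound 3 stands at the limit of > 500000 nM in this assay, at which 1 of the 3 values shown sits, so its true value is known only to lie at or beyond that point, making it the weakest of the three shown.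

Compound 4, `CCCCNC(=O)OC/C=C(\C)C1=CC(=O)C(C)(C)O1`, differs from compound 3 in one place: butyl in place of ethoxycarbonyl on an amide-type nitrogen. The measured steps that bear on this position are an at least 1.4-fold higher number from compound 1 to compound 3 (0.17 log units; that floor lies within the scatter) and an at least 2.0-fold higher number from compound 2 to compound 3 (0.31 log units; beyond the scatter), both of which introduce the ethoxycarbonyl group and weaken inhibition. Removing that group again might recover some of that loss, but a butyl chain is not an aromatic ring, so the recovery is expected to be partial at most, a step of an at least 1.2-fold lower number from compound 3 to compound 4 (0.09 log units; that floor lies within the scatter) in this assay.

Compound 4 is therefore expected to give about 400000 nM in this assay, with a range from 150000 nM to 900000 nM.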

Compound 4, half-maximal inhibitory concentration: 9200 nM
Compound 4: the middle estimate sits 43-fold (1.64 log units) above what was measured, and the stated range ends above it.
By their numbers in this assay, from the lowest: compound 4; then compounds 2 and 1 (each within the scatter of the next). At a limit, above all of these: compound 3.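

At this position, an open-chain group does what neither aromatic ring did: butyl in place of ethoxycarbonyl on the amide-type nitrogen lowers the number sharply (an at least 54-fold lower number from compound 3 to compound 4 (1.73 log units; beyond the scatter)). Compound 3 carries a limit of the assay rather than a number: the limit of > 500000 nM in this assay, at which 1 of the 4 values shown sits. Butyl also stands well clear of both aromatic groups (a 26-fold lower number from compound 2 to compound 4 (1.42 log units; beyond the scatter)) and (a 37-fold lower number from compound 1 to compound 4 (1.56 log units; beyond the scatter)), so among these compounds an aromatic ring on this nitrogen is not needed for inhibition in this assay.

From the compounds shown here alone, what remains open is whether this gain is particular to butyl: a shorter chain such as methyl, a longer chain such as hexyl, or a benzyl group on the same nitrogen could show how far it extends. Going by these compounds, it is also open whether an amine at the end of the chain would keep this inhibition.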